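Swapping the amide-side heteroaryl while keeping the naphthalenyl arm

This account rests on a few compounds, and the source may have more. Where it says the series, first, only, none or still open, it means among the compounds named here.

Compound 3 `O=C(Cn1c(-c2ccccc2)cc(-c2cccc3ccccc23)c1-c1ccco1)Nc1nc2ccccc2s1` stands lowest of the three numbers measured in an ADME assay on HEK-293T cells (Homo sapiens) for cytotoxicity, read by MTT assay, with a stated time of 72 h, tested at 50 uM; on this read-out higher numbers stand for more inhibition at the one concentration tested (going by the name of the read-out) and lower numbers for less inhibition: compound 3 gives 68.8%, while compound 1 `CCc1nnc(NC(=O)Cn2c(-c3ccccc3)cc(-c3ccccc3)c2-c2ccco2)s1` gives 81% and compound 2 `CCc1nnc(NC(=O)Cn2c(-c3ccccc3)cc(-c3ccco3)c2-c2ccco2)s1` gives 90.2%, both beyond the scatter away from compound 3. Within the data shown here, the only measured step, a number 9.2 percentage points higher from compound 1 to compound 2 (within the scatter), concerns an aromatic carbon far from the amide and so does not bear directly on the change considered here.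

Compound 4 `CCc1nnc(NC(=O)Cn2c(-c3ccccc3)cc(-c3cccc4ccccc34)c2-c2ccco2)s1` differs from compound 3 in one place: 5-ethyl-1,3,4-thiadiazol-2-yl in place of 1,3-benzothiazol-2-yl on an amide-type nitrogen. Among the measured compounds shown here, no measured pair isolates this exchange. What the numbers do show is that both compounds carrying 5-ethyl-1,3,4-thiadiazol-2-yl on the amide-type nitrogen, compound 1 and compound 2, sit above compound 3, which is the sole bearer of 1,3-benzothiazol-2-yl. On that basis the author expects an upward step, a number 10.2 percentage points higher from compound 3 to compound 4 (beyond the scatter), in this assay, though its size is uncertain. The estimate for compound 4 in this assay is 79%, expected to lie between 62% and 93%.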

Compound 4, a percentage reported as inhibition, at one concentration (the size of the read-out at that concentration, not a potency): 59.7%
For compound 4 the middle estimate is 19.3 percentage points above the measured one, and the stated range ends above it.
By their numbers in this assay, from the lowest: compounds 4 and 3 (each within the scatter of the next); then compounds 1 and 2 (each within the scatter of the next).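

In this assay, among these compounds, the first direct pair for this exchange on the amide-type nitrogen, 5-ethyl-1,3,4-thiadiazol-2-yl in place of 1,3-benzothiazol-2-yl, gives a number 9.1 percentage points lower from compound 3 to compound 4 (within the scatter), so these two groups are not told apart with naphthalen-1-yl held in place. The steps beyond the scatter come instead from the aromatic carbon, where naphthalen-1-yl in place of furan-2-yl gives a number 30.5 percentage points lower from compound 2 to compound 4 (beyond the scatter) and naphthalen-1-yl in place of phenyl gives a number 21.3 percentage points lower from compound 1 to compound 4 (beyond the scatter). Nothing available here explains these differences.

On these data alone, whether the amide-side exchange would give a similar step with phenyl or furan-2-yl on that aromatic carbon remains open. So does the effect of a longer chain in place of the ethyl group, or of a terminal carboxylic acid or amine on that chain.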